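The source may hold more compounds than are shown below. What is called first, only, known or untested is meant among the compounds shown, and "the series" means these compounds.

Going by the values given here, in a functional assay on MKN-45 cells (Homo sapiens) for antiproliferative activity (on this read-out lower numbers stand for stronger inhibition and higher numbers for weaker inhibition), compound 2 (`COc1ccc(S(=O)(=O)N2CCc3cccc(Nc4ccccc4)c32)cc1`) gives 187 nM, the lower of the two numbers so far, while compound 1 (`COc1ccc(S(=O)(=O)N2CCc3cccc(Nc4ccc(O)cc4)c32)cc1`) gives 493 nM. The next analogue, compound 3 (`COc1ccc(Nc2cccc3c2N(S(=O)(=O)c2ccc(OC)cc2)CC3)cc1`), carries methoxy in place of hydrogen on an aromatic carbon of the anilino group, para to a large group: methoxy in place of hydrogen on an aromatic carbon. Among the compounds with values here, one measured step bears on this change: a 2.6-fold lower number from compound 1 to compound 2 (0.42 log units; beyond the scatter), a modest step in which hydrogen takes the place of hydroxy on an aromatic carbon. Within the data shown here, no methoxy analogue has been measured, and a step involving hydroxy is only a weak guide to methoxy. No clear step beyond the scatter is expected, and the estimated step is a 1.1-fold higher number from compound 2 to compound 3 (0.03 log units; within the scatter). In this assay, compound 3 is expected at 200 nM, with an estimated range from 70 nM to 600 nM.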

Compound 3, half-maximal inhibitory concentration: 487 nM
Compound 3: the middle estimate sits 2.4-fold (0.39 log units) below what was measured; the range from low to high includes it.
By their numbers in this assay, from the lowest: compound 2; then compounds 3 and 1 (each within the scatter of the next).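

At this position of the anilino group, para to a large group, methoxy in place of hydrogen gives a 2.6-fold higher number from compound 2 to compound 3 (0.42 log units; beyond the scatter) in this assay and so places a second oxygen-bearing analogue apart from the unsubstituted phenyl of compound 2. Methyl in place of hydrogen on the oxygen gives a 1.0-fold lower number from compound 1 to compound 3 (0.01 log units; within the scatter) and so leaves hydroxy and methoxy indistinguishable here, which means the hydrogen on that oxygen does not separate this pair. Nothing measured on hand accounts for the gap to compound 2.

Still open, from the compounds shown here alone, is whether the higher number goes with oxygen on this carbon or with any group larger than hydrogen. A methyl, a fluorine or an amine on the same carbon would tell these two readings apart.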